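The compounds below may be only part of what the source reports. "The series", "measured", "known", "first", "only" and "open" are said of these compounds alone.

Compound 1 `Cc1ccc([C@@H](C)Oc2cc3onc(CCC(=O)O)c3cc2Cl)nn1`: 230 ug/mL
Compound 2 `CCOc1cc2oc(=O)n(CCC(=O)O)c2cc1Cl`: > 1880 ug/mL

Among the measured compounds shown here, in a physicochemical assay for solubility, with a stated time of 24 h (on this read-out higher numbers stand for higher solubility and lower numbers for lower solubility), compound 1 gives 230 ug/mL, the only actual number so far. Compound 2 gives > 1880 ug/mL, which is a limit of the assay and not a number.

Compound 3 `C[C@@H](Oc1cc2onc(CCC(=O)O)c2cc1Cl)c1ccccn1` has pyridin-2-yl in place of 6-methylpyridazin-3-yl on a saturated chain carbon bound to an oxygen on an aromatic ring and a saturated chain carbon.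

For the measured compounds named here, no measured pair tests this swap, so the expectation rests on compound 1 alone, at 230 ug/mL. In this assay, a small downward step within the usual scatter is expected: a 1.5-fold lower number from compound 1 to compound 3 (0.19 log units; within the scatter). For compound 3 the estimated value is 150 ug/mL, with an expected range from 50 ug/mL to 450 ug/mL.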

Compound 3, solubility: > 7440 ug/mL
Compound 3: no number, only a limit; the forecaster's own chance of this, stated with the estimate: 5%; at least 49-fold (1.69 log units) between middle value and limit.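

In this assay, pyridin-2-yl in place of 6-methylpyridazin-3-yl gives an at least 32-fold higher number from compound 1 to compound 3 (1.50 log units; beyond the scatter). This is the first single change shown at this place, and it moves the read-out far more than repeat measurements would. Compound 3 gives no number, only a limit of the assay, so the full size of the step stays unknown: the limit of > 7440 ug/mL in this assay, at which 1 of the 3 values shown sits.

The swap both removes the methyl and changes the ring nitrogens, and the compounds shown cannot separate the two. Pyridazin-3-yl without the methyl, or 6-methylpyridin-2-yl, at this place would bear on that question.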